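The compounds below may be only part of what the source reports. "The series", "measured", "known", "first", "only" and "open" are said of these compounds alone.

Measured so far in an assay on isolated protein (Bos taurus) with 5-hydroxytryptamine receptor 1D (Homo sapiens) as the target; a lower number here means a stronger inhibitor, a higher number a weaker inhibitor:
- compound 1, `c1cnc(NCCNCC2CCc3ccccc3O2)nc1`, gives 31.6 nM
- compound 2, `c1ccc2c(c1)CC(CNCCCNC1=NCCCN1)O2`, gives 126 nM
- compound 3, `c1ccc2c(c1)CCCC(CNCCCNC1=NCCCN1)O2`, gives > 1000 nM, which is a limit of the assay, not a number

Of the two actual numbers, compound 1 has the lower one; compound 2 sits higher, and that gap is beyond the scatter. Compound 3 only shows (the limit of > 1000 nM in this assay, at which 1 of the 3 values shown sits), so it says nothing about a size of step.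

Compound 4, `c1ccc2c(c1)CCC(CNCCCNc1nccs1)O2`, has not yet been measured. It differs from compound 1 by ((1,3-thiazol-2-yl)amino)methyl in place of (pyrimidin-2-yl)amino on a saturated chain carbon, two bonds along the chain from an amine nitrogen. For the measured compounds named here, there is no measured pair that isolates this change, so the size of the step from compound 1 to compound 4 is estimated, not read off. Compound 2 carries the same longer chain and a different ring at its end, and its value of 126 nM gives a rough anchor for where a longer-chain compound may land. On that basis the step is expected to be a modest rise, a 2.5-fold higher number from compound 1 to compound 4 (0.40 log units; beyond the scatter). Compound 4 is therefore expected to give 80 nM, with a range from 20 nM to 400 nM.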

Compound 4, half-maximal inhibitory concentration: 7.94 nM
Estimate against measurement, compound 4: 10-fold (1.00 log units) above; the measured number lies below the stated range.
By their numbers in this assay, from the lowest: compound 4; then compound 1; then compound 2. At a limit, above all of these: compound 3.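

In this assay, putting ((1,3-thiazol-2-yl)amino)methyl in place of (pyrimidin-2-yl)amino on a saturated chain carbon, two bonds along the chain from an amine nitrogen, gives a 4.0-fold lower number from compound 1 to compound 4 (0.60 log units; beyond the scatter). For the compounds shown here, this is the first step that can be read from a pair differing in one place, and it shows that this end of the chain accepts a longer reach and a five-membered aromatic ring with sulfur without any loss in this assay, even though the two groups have the same counts of heavy atoms, hydrogen-bond donors and hydrogen-bond acceptors. Nothing measured here explains the direction or size of this step.

The ring and the chain length change together in this one step, so the compounds shown do not separate their contributions; that would take the pyrimidin-2-yl group on the longer chain, or the 1,3-thiazol-2-yl group on the shorter one. From the compounds shown here alone, how a pyridine ring, a plain amine or a still longer chain would behave at this position also remains open.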